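Macrophage Cytotoxicity: Following Compound 3 to Compound 4

A few compounds are considered here, and "the series" means these few. Any claim that something is new, unique, unknown or untested is made for them only; others in the source may bear on it.

Compound 1 `O=C1OC(Cc2nc(-c3ccc(Oc4ccccc4)cc3)no2)c2ccccc21` gives a limit of > 40000 nM in an ADME assay on RAW264.7 cells (Mus musculus) for cytotoxicity, read by MTT assay, with a stated time of 24 h, in the absence of a further agent; a lower number here means a stronger inhibitor, a higher number a weaker inhibitor.
Compound 2 `O=C1OC(Cc2nc(-c3ccc(-c4ccccc4)cc3)no2)c2ccccc21` gives a limit of > 40000 nM in this assay.
Compound 3 `COCCCCOc1ccc(C(O)C2OC(=O)c3c(OC)cc(OC)cc32)cc1` gives a limit of > 40000 nM in this assay.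

Compound 3 thus stands at the limit of this assay, and no number is known for it; the same holds for the other two compounds, as the limit of > 40000 nM in this assay, at which 3 of the 3 values shown sit, records. Among the measured compounds shown here, the only step between measured compounds, a step that the two limits leave unreadable from compound 1 to compound 2, cannot be read, and it concerns a different change from the one ahead. Compound 4 `COc1cc(OC)c2c(c1)C(C(O)c1ccc(OCc3ccc(C#N)cc3)cc1)OC2=O` differs from compound 3 by 4-cyanophenyl in place of 3-methoxypropyl on a saturated chain carbon bound to an oxygen on an aromatic ring. With every measured value at the limit, no readable step bears on this change, and compound 4 is expected to remain at the limit, with an estimated step that the limit leaves unreadable from compound 3 to compound 4. The estimate for compound 4 is 60000 nM, ranging from 30000 nM to 150000 nM.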

Compound 4, half-maximal inhibitory concentration: > 40000 nM
Compound 4 was reported as a limit; the forecaster's own chance of this, stated with the estimate: 85%; the middle value does not contradict the limit.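

No step can be read from compound 3 to compound 4, because both are reported only as limits in this assay: the limit of > 40000 nM in this assay, at which 4 of the 4 values shown sit.

The compounds shown leave open whether any of them has a measurable half-maximal inhibitory concentration, and whether any structural change shifts it.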